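A fluorine swap on the sulfonyl aryl group

A few compounds are considered here, and "the series" means these few. Any claim that something is new, unique, unknown or untested is made for them only; others in the source may bear on it.

Compound 1 `Cc1cccc(S(=O)(=O)Nc2ccc(-c3nc4ccccc4o3)cc2)c1` carries a 3-methylphenyl on its sulfonyl sulfur. In an ADME assay on HEK293 cells (Homo sapiens) for cytotoxicity, read by resazurin assay, with a stated time of 48 h (a higher number here means that more compound is tolerated, a lower number that less compound is tolerated), compound 1 gives only a limit, > 100000 nM. Compound 2 `O=S(=O)(Nc1ccc(-c2nc3ccccc3o2)cc1)c1cccc(C(F)(F)F)c1` differs from compound 1 by trifluoromethyl in place of methyl on an aromatic carbon, and in this assay compound 2 likewise gives only a limit, > 100000 nM. The step that the two limits leave unreadable from compound 1 to compound 2 cannot be read, because the limit of > 100000 nM in this assay, at which 2 of the 3 values shown sit, holds both compounds. Compound 3 `O=S(=O)(Nc1ccc2oc(-c3ccccc3)nc2c1)c1cccc(F)c1` differs from compound 1 in several places. In this assay, going by the values given here, compound 3 gives 68000 nM; no single-place step connects it to the other two, so its value can only be set beside theirs.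

Compound 4 `O=S(=O)(Nc1ccc(-c2nc3ccccc3o2)cc1)c1ccc(F)cc1` is the compound to be measured: 4-fluorophenyl in place of 3-methylphenyl on a sulfonyl sulfur. Among the compounds with values here, the only measured step touching a change on the sulfonyl sulfur is the one from compound 1 to compound 2, and its size is not readable. Two of the three values shown sit at the limit, and compound 4 is expected to sit close to it as well. Compound 4 is estimated at 100000 nM in this assay, between 40000 nM and 250000 nM. The expected step of a number no higher from compound 1 to compound 4 (the limit leaves the size open) is thus no larger than the usual scatter.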

Compound 4, half-maximal cytotoxic concentration: > 100000 nM
Compound 4: a limit, no number; the forecaster's own chance of this, stated with the estimate: 75%; the middle value lies on the limit itself.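

In this assay, compound 4 gives only a limit, > 100000 nM. Going by these compounds alone, no step from compound 1 to compound 4 can be read, because both compounds sit at the same point: the limit of > 100000 nM in this assay, at which 3 of the 4 values shown sit. The compounds shown leave open whether 4-fluorophenyl in place of 3-methylphenyl on a sulfonyl sulfur changes how much compound is tolerated in this assay.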